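The compounds below may be only part of what the source reports. "The series", "measured", "known", "first", "only" and "open" are said of these compounds alone.

Measured compounds:
Compound 1 `Cc1ccc(/C=C/c2cccc(F)c2)cc1` gives 800 nM.
Compound 2 `Fc1cccc(/C=C/c2ccc(F)c(F)c2)c1` gives 5000 nM.

Both were tested in an assay on HepG2 cells for activation of nuclear factor erythroid 2-related factor 2 (Homo sapiens), read by a luciferase reporter, with a stated time of 5 h; on this read-out lower numbers stand for an effect already at smaller amounts and higher numbers for an effect only at larger amounts of compound. Compound 2 stands at the higher of the two numbers; compound 1 comes in with a clearly lower number, and the gap between them lies beyond the usual scatter. Within the data shown here, no step between measured compounds that differ in one place is available, so the move to the unmeasured compound 3, `Fc1ccc(/C=C/c2cccc(F)c2)cc1`, rests on the structures alone. The change is hydrogen in place of fluoro on an aromatic carbon. Compound 3 thus keeps one fluoro on each ring and loses the second fluoro on the ring that carries two in compound 2. Compound 1 gives 800 nM and has no ring with two fluoro groups, so a lower number for compound 3 than for compound 2 seems plausible, though the size of the step is uncertain. Compound 3 is expected to reach about 2000 nM in this assay, between 700 nM and 6000 nM, an estimated step of a 2.5-fold lower number from compound 2 to compound 3 (0.40 log units; beyond the scatter) of moderate size toward a smaller number.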

Compound 3, half-maximal effective concentration: 650 nM
Beside the measured number, compound 3's estimate is 3.1-fold (0.49 log units) above it; the whole stated range lies above it.
By their numbers in this assay, from the lowest: compounds 3 and 1 (each within the scatter of the next); then compound 2.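

In this assay, among these compounds, hydrogen in place of fluoro on the aromatic carbon ortho to a fluoro group gives a 7.7-fold lower number from compound 2 to compound 3 (0.89 log units; beyond the scatter), the first direct reading at this position, and it shows that this single exchange is enough to move the number beyond the scatter. On the other ring-bound site that differs, fluoro in place of methyl gives a 1.2-fold lower number from compound 1 to compound 3 (0.09 log units; within the scatter), so this assay does not tell those two groups apart there. Nothing available explains the size of either step.

As far as these compounds go, whether a chlorine atom, a methoxy group or a nitrile on the aromatic carbon that carries the second fluoro would read like hydrogen or like fluoro remains open. From the compounds shown here alone, it also remains open whether a larger change in place of the methyl or fluoro group, such as an amine or a carboxylic acid, would keep the number within the scatter.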